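Fluorocyclopropyl amide on a bicyclic diamine core

The source may hold more compounds than are shown below. What is called first, only, known or untested is meant among the compounds shown, and "the series" means these compounds.

Three amides sharing one bicyclic diamine core have been measured in an assay on CHO cells for displacement of a labelled ligand from Neuronal acetylcholine receptor; alpha3/alpha6/beta2/beta3 (Homo sapiens), read by scintillation counting; on this read-out higher numbers stand for weaker inhibition and lower numbers for stronger inhibition. Compound 1 `CC(=O)N1CC2CC(C1)N2` gives 610 nM. Compound 2 `O=C(C1CCC1)N1CC2CC(C1)N2` gives 240 nM, and compound 3 `O=C(C1CC=CC1)N1CC2CC(C1)N2` gives 1100 nM. Of these three numbers compound 2 holds the lowest, and both of its gaps to the others are beyond the scatter. Among the measured compounds shown here, the one single-point step so far, a 2.5-fold lower number from compound 1 to compound 2 (0.41 log units; beyond the scatter), came from putting cyclobutyl in place of methyl on a carbonyl carbon, a modest step.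

Compound 4 `O=C([C@@H]1C[C@H]1F)N1CC2CC(C1)N2` is not yet measured. It differs from compound 2 in one place: 2-fluorocyclopropyl in place of cyclobutyl on a carbonyl carbon. For the measured compounds named here, no measured pair exchanges one ring for another on that carbonyl carbon, so the earlier step only shows that the group on this carbon can shift the number modestly. On that basis compound 4 is expected to land close to compound 2, with an estimated step of a 1.7-fold higher number from compound 2 to compound 4 (0.22 log units; within the scatter) and an estimated value of 400 nM, between 150 nM and 1200 nM.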

Compound 4, inhibition constant: 43 nM
The estimate for compound 4 lay 9.3-fold (0.97 log units) above the measured number, outside the stated range (below it).
By their numbers in this assay, from the lowest: compound 4; then compound 2; then compounds 1 and 3 (each within the scatter of the next).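

In this assay replacing one ring with another on the carbonyl carbon gives a 5.6-fold lower number from compound 2 to compound 4 (0.75 log units; beyond the scatter) even though cyclobutyl and 2-fluorocyclopropyl each have 4 heavy atoms, so this position responds to the kind of group and not only to its atom count. Starting from the methyl group of compound 1, the change gives a 14-fold lower number from compound 1 to compound 4 (1.15 log units; beyond the scatter) and counts as a large step, whereas cyclobutyl in place of methyl was only a modest one. Nothing available here explains why compound 4 gives the lower number.

From the compounds shown here alone, this single change alters the ring size and adds fluorine together, so the contribution of each remains unknown, and a plain cyclopropyl group would help to separate them. Also open, going by these compounds, are the opposite arrangement at the two stereocentres and the effect of an amine or a hydroxyl group on the ring.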